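The source may report more compounds than this note shows. Statements on the series, on what has been measured and on what is new or still open speak of the compounds shown alone.

Measured compounds:
compound 1 `Cc1nnsc1CO/N=C/c1c(C)nn(C)c1Oc1ccccc1Cl`: in a functional assay on PANC-1 cells (Homo sapiens) for inhibition, read by MTT assay, with a stated time of 48 h (a lower number here means a stronger inhibitor, a higher number a weaker inhibitor), compound 1 sits at the assay limit, > 50000 nM.
compound 2 `Cc1nnsc1CO/N=C/c1c(C)nn(C)c1Oc1cccc(F)c1`: in this assay compound 2 also sits at the limit, > 50000 nM.
compound 3 `Cc1nnsc1CO/N=C/c1c(C)nn(C)c1Oc1ccc(I)cc1`: in this assay compound 3 likewise sits at the limit, > 50000 nM.

Compound 3 therefore stands only at a limit, as do the two other values, all three at the limit of > 50000 nM in this assay, at which 3 of the 3 values shown sit. The three measured steps, a step that the two limits leave unreadable from compound 1 to compound 2, a step that the two limits leave unreadable from compound 1 to compound 3 and a step that the two limits leave unreadable from compound 2 to compound 3, are all unreadable between limits and give no size in either direction. Compound 4 `Cc1cccc(Oc2c(/C=N/OCc3snnc3C)c(C)nn2C)c1` differs from compound 3 by 3-methylphenyl in place of 4-iodophenyl on an oxygen on an aromatic ring. Going by the values given here, none of the measured steps reads a size, so no step beyond the scatter can be expected from them in this assay. The step estimated from compound 3 is a step that the limit leaves unreadable from compound 3 to compound 4, most likely ending again at a limit. Compound 4 is expected at 70000 nM with a range from 20000 nM to 250000 nM.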

Compound 4, half-maximal inhibitory concentration: > 50000 nM
Compound 4 was reported as a limit; the forecaster's own chance of this, stated with the estimate: 80%; the middle value lies beyond the limit too.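

In this assay compound 4 gives > 50000 nM, a limit, so its steps from compound 1, compound 2 and compound 3 cannot be read. The compounds shown leave open how these substituted phenyl groups rank against one another.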